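This account rests on a few compounds, and the source may have more. Where it says the series, first, only, none or still open, it means among the compounds named here.

Compound 1 `COc1cc(-c2ccnc3cc(-c4ccc(C(C)(C)C)cc4)nn23)cc(OC)c1OC` reports only a limit in a functional assay on HCT-116 cells (Homo sapiens) for inhibition, read by CCK-8 assay, with a stated time of 48 h (a lower number here means a stronger inhibitor, a higher number a weaker inhibitor), namely > 10000 nM. Compound 2 `COc1cc(-c2ccnc3cc(-c4ccccc4)nn23)cc(OC)c1OC` gives 3880 nM in this assay, the only number shown in this set. Within the data shown here, the step of an at least 2.5-fold lower number from compound 1 to compound 2 (0.41 log units; beyond the scatter) is the sole measured comparison, and its size is bounded by the limit of > 10000 nM in this assay, at which 1 of the 2 values shown sits. Compound 3 `CCOC(=O)c1ccc(-c2cc3nccc(-c4cc(OC)c(OC)c(OC)c4)n3n2)cc1` differs from compound 2 by ethoxycarbonyl in place of hydrogen on an aromatic carbon. As that change again adds a substituent on an aromatic carbon, the measured step bears on it, and a step toward a higher number in this assay is expected, a 1.5-fold higher number from compound 2 to compound 3 (0.19 log units; within the scatter). Compound 3 is estimated at 6000 nM, within 2000 nM to 20000 nM.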

Compound 3, half-maximal inhibitory concentration: > 10000 nM
Compound 3 was reported as a limit; the forecaster's own chance of this, stated with the estimate: 30%; middle value at least 1.6-fold (0.22 log units) away from the limit.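

In this assay ethoxycarbonyl para to a large group gives an at least 2.5-fold higher number from compound 2 to compound 3 (0.41 log units; beyond the scatter) and so, like tert-butyl, fails to hold the number of the hydrogen compound at this position. The step between compound 1 and compound 3 cannot be read, since both values are limits, so these two groups cannot be ranked. Two quite different substituents now share one outcome, and the true size of each step stays bounded: the limit of > 10000 nM in this assay, at which 2 of the 3 values shown sit.

Open, on these data alone, is whether a smaller group, such as methyl, fluorine or an amine, would keep or lower the number of compound 2. As far as these compounds go, a carboxylic acid at this place is equally open.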